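Butyl in place of trifluoromethyl on the benzyl group

This account rests on a few compounds, and the source may have more. Where it says the series, first, only, none or still open, it means among the compounds named here.

Compound 2 `C/C(=C\C(=O)Nc1ccccc1OCCCC(=O)O)c1ccc2c(ccn2Cc2ccc(C(F)(F)F)cc2)c1` stands at the weaker end of the two numbers available: in an assay on Prostate gland for inhibition of steroid 5-alpha-reductase (Rattus norvegicus) (on this read-out higher numbers stand for weaker inhibition and lower numbers for stronger inhibition), compound 2 gives 300 nM, whereas compound 1 `CCCC(CC)n1ccc2cc(/C(C)=C/C(=O)Nc3ccccc3OCCCC(=O)O)ccc21` gives 9.3 nM. Going by the values given here, the only step so far, a 32-fold higher number from compound 1 to compound 2 (1.51 log units; beyond the scatter), concerns the whole group on the aromatic nitrogen, not the substituent on its benzyl ring. Compound 3 `CCCCc1ccc(Cn2ccc3cc(/C(C)=C/C(=O)Nc4ccccc4OCCCC(=O)O)ccc32)cc1` differs from compound 2 by butyl in place of trifluoromethyl on an aromatic carbon. Among the compounds with values here, no measured pair shows this change, so the direction has to be taken as open; the large step from compound 1 to compound 2 only shows that this region can move the read-out strongly. Compound 3 is therefore estimated to stay near compound 2, with a 1.5-fold lower number from compound 2 to compound 3 (0.18 log units; within the scatter), and to give 200 nM in this assay, within a range from 40 nM to 1000 nM.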

Compound 3, half-maximal inhibitory concentration: 100 nM
The estimate for compound 3 lay 2.0-fold (0.30 log units) above the measured number; measured number inside the range.
By their numbers in this assay, from the lowest: compound 1; then compound 3; then compound 2.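

In this assay, the substituent on the benzyl ring itself moves the number: butyl in place of trifluoromethyl, each of 4 heavy atoms, gives a 3.0-fold lower number from compound 2 to compound 3 (0.48 log units; beyond the scatter) and so lies beyond the scatter, which the earlier step, spanning the whole group on the aromatic nitrogen, could not show. Butyl closes only part of the gap, since 4-butylbenzyl in place of 1-ethylbutyl still gives an 11-fold higher number from compound 1 to compound 3 (1.03 log units; beyond the scatter) and compound 1 keeps the lowest number of the three. Nothing measured here accounts for either shift.

Going by these compounds, whether a longer chain, a methoxy group, an amine or a carboxylic acid at this place on the benzyl ring would lower the number further or raise it remains open. Also open, on these data alone, is whether a longer branched alkyl chain on the aromatic nitrogen would match 1-ethylbutyl.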